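Swapping fluoro for bromo on a chalcone-like scaffold

The compounds below may be only part of what the source reports. "The series", "measured", "known", "first", "only" and "open" are said of these compounds alone.

Compound 2 `COc1cc(OC)c(C(=O)/C=C/c2ccc(F)cc2)c(OC)c1` gives 1.1% in a functional assay on Huh-7 cells (Homo sapiens), read by fluorescence and BrdU incorporation, with a stated time of 48 h, tested at 25 uM (a higher number here means a weaker effect of the compound at the concentration tested, a lower number a stronger effect), the highest of the two numbers available, with compound 1 `COc1cccc(/C=C/C(=O)c2c(OC)cc(OC)cc2OC)c1` at 0.3% as its nearest neighbour, a gap within the scatter. Among the measured compounds shown here, the only step measured so far, a number 0.8 percentage points higher from compound 1 to compound 2 (within the scatter), exchanged the whole aryl group on the chain and left the read-out essentially unchanged. Compound 3 `COc1cc(OC)c(C(=O)/C=C/c2ccc(Br)cc2)c(OC)c1` differs from compound 2 by a smaller change, (bromo in place of fluoro on an aromatic carbon), sitting para to a large group. For the measured compounds named here, no measured step probes a fluoro-to-bromo exchange itself, but because a number 0.8 percentage points higher from compound 1 to compound 2 (within the scatter) stayed flat across a larger change, no step beyond the scatter is expected here. Compound 3 is therefore expected to give about 1.5% in this assay, within 0% to 12%. The step from compound 2 to compound 3 is estimated as a number 0.4 percentage points higher from compound 2 to compound 3 (within the scatter).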

Compound 3, a percentage reported as activity, at one concentration (the size of the read-out at that concentration, not a potency): 0.2%
For compound 3 the middle estimate is 1.3 percentage points above the measured one; the range from low to high includes it.
By their numbers in this assay, from the lowest: compounds 3, 1 and 2 (each within the scatter of the next).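

In this assay, among the compounds shown here, the exchange of the two halogens on this aromatic carbon, para to a large group, gives a number 0.9 percentage points lower from compound 2 to compound 3 (within the scatter) and is the first direct reading of this change. The wider exchange of the whole aryl group, now with 4-bromophenyl on the chain, gives a number 0.1 percentage points lower from compound 1 to compound 3 (within the scatter) and so also leaves the read-out flat, which means that at this single concentration the 3-methoxyphenyl, 4-fluorophenyl and 4-bromophenyl compounds cannot be told apart. Nothing available offers a reason for this flatness.

Going by these compounds, what remains open is whether a group of another kind on this aromatic carbon, such as an amine or a carboxylic acid, would move the number beyond the scatter. Also open, on these data alone, is whether these three compounds would separate at lower concentrations.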